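The source may hold more compounds than are shown below. What is called first, only, known or untested is meant among the compounds shown, and "the series" means these compounds.

Compound 1 `COc1ccc(/C=C/C(=O)c2ccccc2-c2ccc(F)cc2)cc1OC`: 440 nM
Compound 2 `COc1ccc(/C=C/C(=O)c2ccccc2-c2ccc(F)nc2)cc1OC`: 1200 nM
Compound 3 `COc1ccc(C(=O)/C=C/c2ccccc2-c2ccc(F)cc2)cc1OC`: 7500 nM

These three values come from a functional assay on A549 cells (Homo sapiens) for antiproliferative activity, read by sulforhodamine B assay, with a stated time of 48 h; a higher number here means a weaker inhibitor, a lower number a stronger inhibitor. The change from compound 1 to compound 2 is 6-fluoropyridin-3-yl in place of 4-fluorophenyl on an aromatic carbon, and it produced a 2.7-fold higher number from compound 1 to compound 2 (0.44 log units; beyond the scatter). Compound 3 is built from the same atoms as compound 1, joined differently; the difference between the two cores is not broken down here. Among the three, compound 3 gives the highest number, with compound 2 nearest and compound 1 furthest from it in this assay.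

Compound 4 `COc1ccc(C(=O)/C=C/c2ccccc2-c2ccc(F)nc2)cc1OC` has not yet been measured. It differs from compound 3 by 6-fluoropyridin-3-yl in place of 4-fluorophenyl on an aromatic carbon, the same change already seen between compound 1 and compound 2. A step of a 2.7-fold higher number from compound 3 to compound 4 (0.43 log units; beyond the scatter) is expected because the same change gave a 2.7-fold higher number from compound 1 to compound 2 (0.44 log units; beyond the scatter). Compound 4 is therefore estimated at 20000 nM, likely between 8000 nM and 50000 nM.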

Compound 4, half-maximal inhibitory concentration: 17000 nM
Beside the measured number, compound 4's estimate is 1.2-fold (0.07 log units) above it; measured number inside the range.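

In this assay, 6-fluoropyridin-3-yl in place of 4-fluorophenyl gave a 2.3-fold higher number from compound 3 to compound 4 (0.36 log units; beyond the scatter), and the step carried over from one core to the other at much the same size: the same change on two cores in this assay, a 2.7-fold higher number (0.44 log units; beyond the scatter) from compound 1 to compound 2 and a 2.3-fold higher number (0.36 log units; beyond the scatter) from compound 3 to compound 4, 1.2-fold (0.08 log units) apart, within the scatter of two such steps
On these two cores, then, the change can be treated as transferable, with the same direction and a matching size. Two cores in a single assay do not show that it would transfer to other cores in the series, and they say nothing about why the step has this size.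

The compounds shown leave open how other groups would behave at this aromatic carbon. An amine or a carboxylic acid in place of the fluorine on the ring is one such case.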